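Swapping Hydroxy for Azetidine on the Pyridine Arm

The source may hold more compounds than are shown below. What is called first, only, known or untested is meant among the compounds shown, and "the series" means these compounds.

Three measured compounds share one core and differ in a single aromatic group. Compound 1 `O=C(O)Cc1sc(C(c2ccc(F)cc2)c2ccc(F)cc2)nc1-c1ccnc(Cl)c1` gives 80% in an in vitro functional assay on HEK285-7 cells for antagonist activity at prostaglandin D2 receptor 2 (Homo sapiens), read by BRET and beta-arrestin recruitment; a higher number here means a larger maximal response, a lower number a smaller maximal response. Compound 2 `NS(=O)(=O)c1cccc(-c2nc(C(c3ccc(F)cc3)c3ccc(F)cc3)sc2CC(=O)O)c1` gives 55%, and compound 3 `O=C(O)Cc1sc(C(c2ccc(F)cc2)c2ccc(F)cc2)nc1-c1ccnc(O)c1` gives 60%. Compound 3 therefore stands second highest of the three: its gap to compound 2 lies within the scatter (a number 5 percentage points higher from compound 2 to compound 3 (within the scatter)), while the other gap is larger (a number 20 percentage points lower from compound 1 to compound 3 (beyond the scatter)). Compound 4 `O=C(O)Cc1sc(C(c2ccc(F)cc2)c2ccc(F)cc2)nc1-c1ccnc(N2CCC2)c1` changes the same group: azetidin-1-yl in place of hydroxy on an aromatic carbon. Among the measured compounds shown here, only the step from compound 1 to compound 3 touches this position, and it was modest. For the measured compounds named here, no measured step covers azetidin-1-yl, so the direction is uncertain. Compound 4 is expected to give 70%, between 50% and 90%, an estimated step of a number 10 percentage points higher from compound 3 to compound 4 (within the scatter).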

Compound 4, largest response reached (reported as efficacy), in percent of the reference or control that the assay uses: 80%
Compound 4: the middle estimate sits 10 percentage points below what was measured; the range from low to high includes it.
By their numbers in this assay, from the lowest: compounds 2 and 3 (each within the scatter of the next); then compounds 1 and 4 (each within the scatter of the next).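

On this aromatic carbon next to the ring nitrogen, azetidin-1-yl separates itself from hydroxy in this assay (a number 20 percentage points higher from compound 3 to compound 4 (beyond the scatter)). It also separates itself from the 3-sulfamoylphenyl group at the same place (a number 25 percentage points higher from compound 2 to compound 4 (beyond the scatter)). Chloro and azetidin-1-yl, although very different groups, cannot be told apart here (no change at the digits printed from compound 1 to compound 4 (within the scatter)). Still open, as far as these compounds go, is whether a simple amine, a pyrrolidine ring or a longer carbon chain on this carbon would give a similar response. Nothing available here explains these steps.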